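Shortening the thioether chain toward an ethynyl group

The source may report more compounds than this note shows. Statements on the series, on what has been measured and on what is new or still open speak of the compounds shown alone.

Measured so far in an assay on RAW264.7 cells for antagonist activity at Toll-like receptor 2 (Mus musculus), read by Griess assay, with a stated time of 24 h; a lower number here means a stronger inhibitor, a higher number a weaker inhibitor:
Compound 1, `C=CCCSC[C@H](N)C(=O)OC`: 45500 nM
Compound 2, `C=CCSC[C@H](NC(=O)c1cc(OC)c(OC)c(OC)c1)C(=O)OC`: 49300 nM
Compound 3, `C=CCCSC[C@H](NC(=O)c1cc(OC)c(OC)c(OC)c1)C(=O)OC`: 27300 nM

Compound 3 gives the lowest of the three numbers in this assay, but the gaps to compound 1 and compound 2 both lie within the scatter, so no order among them can be claimed. Compound 4, `C#CCSC[C@H](NC(=O)c1cc(OC)c(OC)c(OC)c1)C(=O)OC`, differs from compound 3 by ethynyl in place of allyl on a saturated chain carbon bound to a sulfur. Among the compounds with values here, the only step measured at this place is a 1.8-fold lower number from compound 2 to compound 3 (0.26 log units; within the scatter), and it stayed within the scatter. The step to compound 4 again alters the chain at the same carbon, so the expectation is likewise no change beyond the scatter, that is a 1.3-fold higher number from compound 3 to compound 4 (0.11 log units; within the scatter). Compound 4 is therefore estimated at 35000 nM, with a range from 15000 nM to 80000 nM.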

Compound 4, half-maximal inhibitory concentration: 53200 nM
Beside the measured number, compound 4's estimate is 1.5-fold (0.18 log units) below it; measured number inside the range.
By their numbers in this assay, from the lowest: compounds 3, 1, 2 and 4 (each within the scatter of the next).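

In this assay, the triple bond of ethynyl proved no different from the double bond it replaced at this carbon, both against allyl (a 1.9-fold higher number from compound 3 to compound 4 (0.29 log units; within the scatter)) and against vinyl (a 1.1-fold higher number from compound 2 to compound 4 (0.03 log units; within the scatter)). Across compound 2, compound 3 and compound 4, then, all three changes to the group on the sulfur stay within the scatter. No supporting measurement is available to explain these small steps. On these data alone, whether an amine, a carboxylic acid or a longer chain at this place would move the number beyond the scatter remains open.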